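Carbamate series: aryloxy variation and expected inhibition

This account rests on a few compounds, and the source may have more. Where it says the series, first, only, none or still open, it means among the compounds named here.

Measured compounds:
compound 1, `N#Cc1cccc(OC(=O)N2CCC(OC(c3ccccc3)c3ccccc3)CC2)c1`, 120 nM
compound 2, `N#Cc1cc(O)cc(OC(=O)N2CCC(C(c3ccccc3)c3ccccc3)CC2)c1`, 98.2 nM

Going by the values given here, in an assay on isolated protein for inhibition of Monoglyceride lipase (Rattus norvegicus), read by fluorescence, with stated times of 15 min and 3 h (a higher number here means a weaker inhibitor, a lower number a stronger inhibitor), compound 2 gives 98.2 nM, the lowest of the two numbers so far. In this assay compound 1 gives 120 nM; the two values lie within the scatter of one another, so no order between compound 1 and compound 2 is claimed.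

Compound 3, `N#Cc1ccc(F)c(OC(=O)N2CCC(C(c3ccccc3)c3ccccc3)CC2)c1`, has not yet been measured in this assay. It differs from compound 2 in one place: 5-cyano-2-fluorophenyl in place of 3-cyano-5-hydroxyphenyl on an oxygen next to a carbonyl group. Among the compounds with values here, no step between measured compounds that differ in one place is available in this assay, so the change from compound 2 to compound 3 has no measured precedent here.

The expected step is a 1.5-fold higher number from compound 2 to compound 3 (0.18 log units; within the scatter), estimated to stay within the scatter, with no direction asserted. For compound 3 the estimated value in this assay is 150 nM, expected to fall between 40 nM and 550 nM.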

Compound 3, half-maximal inhibitory concentration: 112 nM
Compound 3: middle estimate off by 1.3-fold (0.13 log units), on the high side; the measured number falls inside the stated range.
By their numbers in this assay, from the lowest: compounds 2, 3 and 1 (each within the scatter of the next).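

In this assay, going by these compounds alone, 5-cyano-2-fluorophenyl in place of 3-cyano-5-hydroxyphenyl on an oxygen next to a carbonyl group gives a 1.1-fold higher number from compound 2 to compound 3 (0.06 log units; within the scatter), the first step between compounds that differ in one place. This position therefore accepts a swap of hydroxy for fluorine, and a shift of the nitrile within the ring name, with the hydrogen-bond donor count going from 1 to 0, and the step stays within the scatter, so it is read as neither a gain nor a loss. Nothing available offers an explanation for this result.

As far as these compounds go, whether an amine, a carboxylic acid or a methoxy group on this ring would keep the number in the same range remains open. So does whether a phenyl group without a nitrile would do so.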